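Butyl in Place of Isopropyl on the Shared Core

A few compounds are considered here, and "the series" means these few. Any claim that something is new, unique, unknown or untested is made for them only; others in the source may bear on it.

Of the compounds shown here, two have been measured in a functional assay on NCI-H460 cells (Homo sapiens) for antiproliferative activity, read by CCK-8 assay, with a stated time of 72 h, tested at 2 uM; on this read-out higher numbers stand for a stronger effect at the one concentration tested and lower numbers for a weaker effect. Compound 1 `CC(C)n1cnc2c(Nc3ccccc3)nc(NCOCc3ccc(C(=O)Nc4ccccc4N)cc3)nc21` gives 15% in this assay, and compound 2 `CC(C)n1cnc2c(Nc3cccc(Cl)c3)nc(NCOCc3ccc(C(=O)Nc4ccccc4N)cc3)nc21` gives 28.9%. Among the measured compounds shown here, compound 2 thus stands highest of the two numbers, with compound 1 as its only neighbour; the step of a number 13.9 percentage points higher from compound 1 to compound 2 (beyond the scatter) came with chloro in place of hydrogen on an aromatic carbon.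

Compound 3 `CCCCn1cnc2c(Nc3cccc(Cl)c3)nc(NCOCc3ccc(C(=O)Nc4ccccc4N)cc3)nc21` has not yet been measured. It differs from compound 2 in one place: butyl in place of isopropyl on an aromatic nitrogen. The change sits on an aromatic nitrogen of a five-membered aromatic ring with two nitrogen, part of a fused system of two rings. For the measured compounds named here, no measured step touches this nitrogen or exchanges one chain for another; the one known step concerns a different part of the shared core and so gives no guide to the size or direction of this change. The step from compound 2 to compound 3 is therefore expected to stay within the scatter, as a number 0.1 percentage points higher from compound 2 to compound 3 (within the scatter). Compound 3 is estimated to give 29% in this assay, within a range from 14% to 46%.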

Compound 3, a percentage reported as inhibition, at one concentration (the size of the read-out at that concentration, not a potency): 56.9%
Estimate against measurement, compound 3: 27.9 percentage points below; the measured number lies above the stated range.
By their numbers in this assay, from the lowest: compound 1; then compound 2; then compound 3.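

The chain on this aromatic nitrogen is not a silent feature of the shared core: in this assay, butyl in place of isopropyl gives a number 28 percentage points higher from compound 2 to compound 3 (beyond the scatter), a step beyond the scatter. Among the compounds shown here, until now, the only known change was chloro in place of hydrogen on an aromatic carbon, a number 13.9 percentage points higher from compound 1 to compound 2 (beyond the scatter), so this result adds a second place where one change moves the number, this time through a simple carbon chain with no hydrogen-bond donors or acceptors on either side of the swap. No measurement shown here gives a reason for this step.

With only isopropyl and butyl to compare at this nitrogen, the data cannot separate the effect of one extra carbon from that of a straight chain replacing a branched one, and a propyl group would help to tell these apart, while a longer chain such as hexyl or a chain ending in an amine would show how far the trend extends. As far as these compounds go, it also remains open whether butyl gives a similar step on the compound without the chloro group, the core of compound 1.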